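Adding a Second Methoxy Group to Compound 2

A few compounds are considered here, and "the series" means these few. Any claim that something is new, unique, unknown or untested is made for them only; others in the source may bear on it.

Compound 1 `COc1ccc(-c2nc(C)oc2C(=O)N2CCN(c3cccc(Cl)c3)CC2)cc1`, in a functional assay on HL-60 cells (Homo sapiens) for inhibition, read by MTT assay, with a stated time of 72 h; a higher number here means a weaker inhibitor, a lower number a stronger inhibitor: "not active" (no number reported)
Compound 2 `CCc1nc(-c2ccc(OC)cc2)c(C(=O)N2CCN(c3cccc(Cl)c3)CC2)o1`, in this assay: > 1000 nM
Compound 3 `Cc1nc(-c2ccccc2)c(C(=O)N2CCN(c3cccc(Cl)c3Cl)CC2)o1`, in this assay: 133 nM

Compound 2 stands at a limit of this assay rather than at a number, and this is where the entry the limit of > 1000 nM in this assay, at which 1 of the 3 values shown sits, places it. Compound 1 likewise carries no number and is recorded only as not active. Compound 3 is the only one of the three with a measured value, 133 nM. Between these compounds no single-point steps are recorded, so their values can only be read side by side.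

Compound 4 `CCc1nc(-c2ccc(OC)c(OC)c2)c(C(=O)N2CCN(c3cccc(Cl)c3)CC2)o1` differs from compound 2 in one place: methoxy in place of hydrogen on an aromatic carbon.

Among the compounds with values here, with no recorded step to draw on and compound 2 sitting at a limit, the account can only say what is expected. The change is small and adds a group of the same kind already present, so the step from compound 2 to compound 4 is expected to be none beyond the scatter, with compound 4 remaining weak. The expected shift is a step that the limit leaves unreadable from compound 2 to compound 4. Compound 4 is therefore estimated at 2000 nM, within a range from 500 nM to 8000 nM, and a result reported only as a limit is thought likely.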

Compound 4, half-maximal inhibitory concentration: "not active" (no number reported)
Compound 4 has no reported number here; no gap can be computed for the estimate.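

Compound 4 carries no number in this assay, so no step from compound 2 to it can be read, because compound 2 also stands only at a limit: the limit of > 1000 nM in this assay, at which 1 of the 4 values shown sits.

The compounds shown leave open whether the change from 4-methoxyphenyl to 3,4-dimethoxyphenyl shifts inhibition at all.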